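Adding a second methoxy to compound 3

A few compounds are considered here, and "the series" means these few. Any claim that something is new, unique, unknown or untested is made for them only; others in the source may bear on it.

- compound 1 `COc1cc(OC)c(C(=O)/C=C/c2ccc(F)cc2)c(OCC=C(C)C)c1` at 3200 nM
- compound 2 `COc1cc(OC)c(C(=O)/C=C/c2cccc(Cl)c2Cl)c(OCC=C(C)C)c1` at 1900 nM
- compound 3 `COc1cccc(/C=C/C(=O)c2c(OC)cc(OC)cc2OCC=C(C)C)c1` at 7700 nM

In a functional assay on HCT-116 cells (Homo sapiens) for antiproliferative activity, read by sulforhodamine B assay, with a stated time of 48 h (a lower number here means a stronger inhibitor, a higher number a weaker inhibitor), compound 3 gives 7700 nM and is the weakest inhibitor of the three. The steps that reach it are a 2.4-fold higher number from compound 1 to compound 3 (0.38 log units; beyond the scatter) and a 4.1-fold higher number from compound 2 to compound 3 (0.61 log units; beyond the scatter). The remaining step, a 1.7-fold lower number from compound 1 to compound 2 (0.23 log units; within the scatter), does not separate compound 1 from compound 2.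

Compound 4 `COc1cc(/C=C/C(=O)c2c(OC)cc(OC)cc2OCC=C(C)C)cc(OC)c1` differs from compound 3 by one change: methoxy in place of hydrogen on an aromatic carbon. A methoxy takes the place of a hydrogen on an aromatic carbon, turning 3-methoxyphenyl into 3,5-dimethoxyphenyl.

Among the measured compounds shown here, no measured pair shows this change alone, so the three steps offer only indirect guidance. Each swaps one whole aryl group for another, and even the largest, a 4.1-fold higher number from compound 2 to compound 3 (0.61 log units; beyond the scatter), is modest. A small change to the same ring is therefore expected to produce a step no larger than those. The direction is uncertain, with only a slight lean towards a lower number, since compound 3 already has the highest value. The expected step is a 1.2-fold lower number from compound 3 to compound 4 (0.07 log units; within the scatter) and could well fall within the usual scatter.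

Compound 4 is estimated at 6500 nM with an expected range from 2800 nM to 14000 nM in this assay.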

Compound 4, half-maximal inhibitory concentration: 3500 nM
The estimate for compound 4 lay 1.9-fold (0.27 log units) above the measured number; measured number inside the range.
By their numbers in this assay, from the lowest: compounds 2, 1 and 4 (each within the scatter of the next); then compound 3.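

The added methoxy, which sits meta to a large group and meta to a methoxy group, gives a 2.2-fold lower number from compound 3 to compound 4 (0.34 log units; beyond the scatter) in this assay. Among the compounds shown here, this is the first direct reading of a single change on this ring: the step is modest but lies beyond the scatter, so turning 3-methoxyphenyl into 3,5-dimethoxyphenyl gives a stronger inhibitor here. It also removes the separation from the other two aryl groups, as a 1.1-fold higher number from compound 1 to compound 4 (0.04 log units; within the scatter) and a 1.8-fold higher number from compound 2 to compound 4 (0.27 log units; within the scatter) both lie within the scatter, leaving 3,5-dimethoxyphenyl indistinguishable from 4-fluorophenyl and 2,3-dichlorophenyl in this assay. No measurement available here explains why the second methoxy shifts the number.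

The compounds shown leave open whether this step depends on methoxy itself, since a hydroxyl, an amine or a longer ethoxy chain on the same aromatic carbon would show whether other groups give a similar shift. As far as these compounds go, all four compounds also share the same core, so it remains open whether the step would hold if that core were changed.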